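This account rests on a few compounds, and the source may have more. Where it says the series, first, only, none or still open, it means among the compounds named here.

Working notes on the series. Compound 1 `O=C(CCc1ccc(C(F)(F)F)cc1)Nc1ccc2nc(N3CCC(NS(=O)(=O)O)C3)ccc2c1` is the reference point; in a functional assay on HEK293 cells for activation of melanin-concentrating hormone receptor 1 (Rattus norvegicus), read by inositol phosphate accumulation (a lower number here means that less compound is needed, a higher number that more compound is needed for the effect), compound 1 gives 50 nM, the lowest of the two single numbers available, the nearest being compound 2 `CC1CCCN1c1ccc2cc(NC(=O)CCc3ccc(C(F)(F)F)cc3)ccc2n1`, which in this assay gives 270 nM. Compound 3 `O=C(CCc1ccc(C(F)(F)F)cc1)Nc1ccc2nc(N3CCCC3)ccc2c1` has two entries in this assay and gives 320 nM; 320 nM (2 entries). Among the compounds with values here, the only measured step out of compound 1 is a 5.4-fold higher number from compound 1 to compound 2 (0.73 log units; beyond the scatter), where 2-methylpyrrolidin-1-yl replaced 3-(sulfoamino)pyrrolidin-1-yl on an aromatic carbon.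

Compound 4 `O=C(CCc1ccc(C(F)(F)F)cc1)Nc1ccc2nc(N3CCCCCC3)ccc2c1` is not yet measured. It differs from compound 1 as follows: azepan-1-yl in place of 3-(sulfoamino)pyrrolidin-1-yl on an aromatic carbon. As with compound 2, the sulfoamino-bearing ring is exchanged for a plain saturated nitrogen ring, here azepan-1-yl. The step to compound 2 and the values of compound 3 both point toward a higher number once 3-(sulfoamino)pyrrolidin-1-yl is gone, and compound 4 is expected to follow the same direction, with an estimated 7.0-fold higher number from compound 1 to compound 4 (0.85 log units; beyond the scatter). In this assay compound 4 is therefore expected to give about 350 nM, with a range from 120 nM to 1000 nM.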

Compound 4, half-maximal effective concentration: 1800 nM
For compound 4 the middle estimate is 5.1-fold (0.71 log units) below the measured one; the whole stated range lies below it.
By their numbers in this assay, from the lowest: compound 1; then compound 2; then compound 4.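

Replacing 3-(sulfoamino)pyrrolidin-1-yl with azepan-1-yl on the aromatic carbon next to the ring nitrogen gives a 36-fold higher number from compound 1 to compound 4 (1.56 log units; beyond the scatter) and is a larger step than any seen earlier in the series. Even without the sulfoamino group, this position is sensitive to the ring placed there: azepan-1-yl in place of 2-methylpyrrolidin-1-yl gives a 6.7-fold higher number from compound 2 to compound 4 (0.82 log units; beyond the scatter) and shows that the number depends on the entering ring as well as on the group that leaves. The data shown offer no measurement that accounts for either step.

As far as these compounds go, it remains open whether a carboxylic acid or a primary amine on the pyrrolidine ring could keep the number near that of compound 1. From the compounds shown here alone, it is also open where piperidin-1-yl would fall relative to azepan-1-yl at this position.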